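A few compounds are considered here, and "the series" means these few. Any claim that something is new, unique, unknown or untested is made for them only; others in the source may bear on it.

Compound 1, `CN(Cc1ccccc1F)C(=O)C1CCN(C(=O)c2ccc(S(C)(=O)=O)c([N+](=O)[O-])c2)CC1`: > 60000 nM
Compound 2, `CN(Cc1ccccc1)C(=O)CNC(=O)c1ccc(S(C)(=O)=O)c([N+](=O)[O-])c1`: > 60000 nM

In an assay on isolated protein for inhibition of thyroid hormone receptor alpha (Homo sapiens), read by fluorescence polarization (a higher number here means a weaker inhibitor, a lower number a stronger inhibitor), compound 1 gives only a limit, > 60000 nM. Compound 2 also reaches only a limit in this assay, > 60000 nM. Both values sit at the limit of > 60000 nM in this assay, at which 2 of the 2 values shown sit, so no step between measured compounds can be drawn, and nothing separates compound 1 from compound 2 on the numbers shown. Compound 3, `CC(C)N(C(=O)C1CCN(C(=O)c2ccc(S(C)(=O)=O)c([N+](=O)[O-])c2)CC1)C(C)C`, carries diisopropylamino in place of (2-fluorobenzyl)(methyl)amino on a carbonyl carbon. With compound 1 at its limit > 60000 nM, compound 3 is expected to show no step beyond the scatter in this assay, which the estimate gives as a step that the limit leaves unreadable from compound 1 to compound 3. For compound 3 the estimated value in this assay is 80000 nM, expected between 30000 nM and 200000 nM.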

Compound 3, half-maximal inhibitory concentration: > 60000 nM
Compound 3: a limit, no number; the forecaster's own chance of this, stated with the estimate: 85%; the middle value does not contradict the limit.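

In this assay, among these compounds, compound 3 gives > 60000 nM which is a limit and not a number, so no step from compound 1 to compound 3 can be read. The compounds shown leave open whether any change to the shared core would give a readable number in this assay at all.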